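One ring exchanged close to the assay limit

The source may report more compounds than this note shows. Statements on the series, on what has been measured and on what is new or still open speak of the compounds shown alone.

Measured in a functional assay on KYSE-410 cells (Homo sapiens) for antiproliferative activity, read by MTT assay, with a stated time of 72 h; on this read-out higher numbers stand for weaker inhibition and lower numbers for stronger inhibition:
Compound 1 `O=C(Nc1cccc(F)c1)c1cc(=O)[nH]c2cc(F)ccc12`: > 20000 nM, a limit
Compound 2 `O=C(Nc1cccc(F)c1)c1cc(=O)[nH]c2cc(C3CC3)ccc12`: > 20000 nM, a limit
Compound 3 `O=C(Nc1cccc(F)c1)c1cc(=O)[nH]c2cc(C3=CCOCC3)ccc12`: 12100 nM

Among the compounds with values here, compound 3 holds the only actual number of the three. Compound 4 `O=C(Nc1cccc(F)c1)c1cc(=O)[nH]c2cc(-c3cccnc3F)ccc12` carries 2-fluoropyridin-3-yl instead, a change described as a group of 7 heavy atoms (5 carbon, 1 nitrogen, 1 fluorine; one six-membered aromatic ring with 1 hetero atom) in place of a group of 6 heavy atoms (5 carbon, 1 oxygen; one six-membered non-aromatic ring with 1 hetero atom), on an aromatic carbon. Earlier exchanges on this aromatic carbon bear on it, but weakly: an at least 1.6-fold lower number from compound 1 to compound 3 (0.21 log units; that floor lies within the scatter) and an at least 1.6-fold lower number from compound 2 to compound 3 (0.21 log units; that floor lies within the scatter), while a step that the two limits leave unreadable from compound 1 to compound 2. None of them brings in an aromatic ring, so no direction can be drawn from them. In this assay the expected result is no step beyond the scatter, with an estimated 1.2-fold lower number from compound 3 to compound 4 (0.08 log units; within the scatter). Compound 4 is estimated at 10000 nM, with an expected range of 4000 nM to 20000 nM.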

Compound 4, half-maximal inhibitory concentration: 11600 nM
Compound 4: the middle estimate sits 1.2-fold (0.06 log units) below what was measured; the range from low to high includes it.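

In this assay, exchanging the non-aromatic ring for an aromatic one at this position leaves the number in place, with a 1.0-fold lower number from compound 3 to compound 4 (0.02 log units; within the scatter). Against cyclopropyl and fluoro, 2-fluoropyridin-3-yl gives an at least 1.7-fold lower number from compound 2 to compound 4 (0.23 log units; that floor lies within the scatter) and an at least 1.7-fold lower number from compound 1 to compound 4 (0.23 log units; that floor lies within the scatter). Both steps are floors only, because compound 1 and compound 2 each stand at a limit of the assay: the limit of > 20000 nM in this assay, at which 2 of the 4 values shown sit.

On these data alone, what remains open is whether the ring fluorine matters, as a plain phenyl or an unsubstituted pyridin-3-yl would show. As far as these compounds go, it is also open whether an amine or a carboxylic acid on this aromatic carbon would give a step beyond the scatter.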